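Three Sulfonyl Compounds at the Cytotoxicity Limit

The source may hold more compounds than are shown below. What is called first, only, known or untested is meant among the compounds shown, and "the series" means these compounds.

compound 1 `CS(=O)(=O)N1CCC2(CC1)OOC1(CCCCC1)OO2`: > 100 ug/mL
compound 2 `CCS(=O)(=O)N1CCC2(CC1)OOC1(CCCCC1)OO2`: > 100 ug/mL
compound 3 `CCCS(=O)(=O)N1CCC2(CC1)OOC(C)(C)OO2`: > 100 ug/mL

In a functional assay on Huh-7 cells (Homo sapiens) for cytotoxicity, read by MTT assay, with a stated time of 72 h (on this read-out lower numbers stand for higher toxicity in this test and higher numbers for lower toxicity in this test), compound 1 gives > 100 ug/mL, which is a limit of the assay and not a number. Compound 2 likewise gives only a limit, > 100 ug/mL. Compound 3 also stands at a limit, > 100 ug/mL. The change methyl in place of hydrogen on a saturated chain carbon bound to a sulfonyl sulfur makes the step that the two limits leave unreadable from compound 1 to compound 2. The difference between the cores of compound 1 and compound 3 is not broken down here. Compound 4 `CCCS(=O)(=O)N1CCC2(CC1)OOC(C)(CC)OO2` is not yet measured; it arises from compound 3 through (methyl in place of hydrogen on a saturated chain carbon bound to a saturated ring carbon). That is the same kind of change as from compound 1 to compound 2, but not the same: there the place was a saturated chain carbon bound to a sulfonyl sulfur, here it is a saturated chain carbon bound to a saturated ring carbon. For the measured compounds named here, the step that the limit leaves unreadable from compound 3 to compound 4 is expected to be small, since the limit of > 100 ug/mL in this assay, at which 3 of the 3 values shown sit, shows every compound so far at the same limit. Compound 4 is thus estimated at 150 ug/mL, between 90 ug/mL and 300 ug/mL.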

Compound 4, half-maximal cytotoxic concentration: > 100 ug/mL
Compound 4 gave a limit, no number (the forecaster's own chance of this, stated with the estimate: 85%); the middle value lies beyond the limit too.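

No step can be read from compound 3 to compound 4, as both values in this assay are limits and not numbers: the limit of > 100 ug/mL in this assay, at which 4 of the 4 values shown sit. The compounds shown leave open whether any change to the sulfonyl chain or the core would give a readable number in this assay.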